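The compounds below may be only part of what the source reports. "The series", "measured", "known", "first", "only" and "open" are said of these compounds alone.

Working notes on the series. Among the compounds with values here, compound 2 `NC1=NC2(CCOCC2)N(OCCCOc2ccc(F)cc2)C(N)=N1` is the only member of the set with a numerical result: in an assay on isolated protein for inhibition of Dihydrofolate reductase (Homo sapiens), read by spectrophotometry, using NADPH, with stated times of 5 s and 6 min (on this read-out higher numbers stand for weaker inhibition and lower numbers for stronger inhibition), compound 2 gives 46.6 nM. Compound 1 `NC1=NC2(CCSCC2)N(OCCCOc2cccc(Cl)c2)C(N)=N1` carries a different core and a 3-chlorophenyl group; for compound 1 this assay reports "not determined" (no result reported). Compound 3 `NC1=NC2(CCSCC2)N(OCCCOc2cc(Cl)c(Cl)cc2Cl)C(N)=N1` shares the core of compound 1 and the 2,4,5-trichlorophenyl group; for compound 3 this assay likewise reports "not determined" (no result reported). No comparison between two measured compounds is therefore available, and nothing can be said about how the aryl group or the core affects the read-out.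

Compound 4 `NC1=NC2(CCOCC2)N(OCCCOc2cc(Cl)c(Cl)cc2Cl)C(N)=N1` keeps the core of compound 2 and differs from it in one place: 2,4,5-trichlorophenyl in place of 4-fluorophenyl on an oxygen on a saturated carbon. Within the data shown here, with no measured pair to anchor the change, the expected step from compound 2 to compound 4 in this assay is set near zero, a 1.2-fold lower number from compound 2 to compound 4 (0.07 log units; within the scatter), which is within the usual scatter. The expected value for compound 4 in this assay is 40 nM, within a range of 12 nM to 130 nM.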

Compound 4, half-maximal inhibitory concentration: 36 nM
Compound 4: middle estimate off by 1.1-fold (0.05 log units), on the high side, and the stated range covers the measured number.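

In this assay, within the data shown here, the first pair with two numbers gives a 1.3-fold lower number from compound 2 to compound 4 (0.11 log units; within the scatter) for 2,4,5-trichlorophenyl in place of 4-fluorophenyl on an oxygen on a saturated carbon. With the core of compound 2 held fixed, this position therefore accepts either aryl group, and the read-out does not separate a single fluorine from three chlorines. Nothing on hand bears on why the two compounds read alike.

The core of compound 1 stays unresolved, since compound 3 reads "not determined" (no result reported) and the exchange of core against compound 4 cannot be read. Also open, going by these compounds, is whether an amine or a carboxylic acid on the aryl ring, or a longer chain in place of the present one, would keep the read-out in this range.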